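Compound 4: hydroxy in place of carbonyl

This account rests on a few compounds, and the source may have more. Where it says the series, first, only, none or still open, it means among the compounds named here.

Compound 1 `COc1ccc(-c2nc(CC(=O)c3cccc(Cl)c3)nc3ccsc23)cn1`: 30000 nM
Compound 2 `COc1ccc(-c2nc(C(F)(F)S(=O)(=O)c3cccc(Cl)c3)nc3ccsc23)cn1`: > 50000 nM (a limit)
Compound 3 `COc1ccc(-c2nc(CS(=O)(=O)c3cccc(Cl)c3)nc3ccsc23)cn1`: > 10000 nM (a limit)

Among the compounds with values here, in an ADME assay on cells (Homo sapiens) for cytotoxicity, read by resazurin assay, with a stated time of 5 days (a lower number here means that less compound is tolerated, a higher number that more compound is tolerated), compound 1 gives 30000 nM, and it is the only one of the three compounds with an actual number. Compound 2 has a limit of > 50000 nM. Compound 3 has a limit of > 10000 nM. No two of these compounds differ in one place only, so the data offer no measured step to serve as a guide.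

Compound 4 `COc1ccc(-c2nc(CC(O)c3cccc(Cl)c3)nc3ccsc23)cn1` has not yet been measured. It differs from compound 1 as follows: (3-chlorophenyl)(hydroxy)methyl in place of (3-chlorophenyl)carbonyl on a saturated chain carbon bound to an aromatic carbon. In words, (3-chlorophenyl)(hydroxy)methyl stands in place of (3-chlorophenyl)carbonyl on a saturated chain carbon bound to an aromatic carbon, and the count of heavy atoms in the group stays the same.

With only compound 1 at 30000 nM as an anchor, no change beyond the usual scatter is expected in this assay. The expected step is no change at the digits printed from compound 1 to compound 4 (within the scatter). For compound 4 the estimated value is 30000 nM, with an expected range of 13000 nM to 60000 nM.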

Compound 4, half-maximal cytotoxic concentration: 31000 nM
Compound 4: the middle estimate sits 1.0-fold (0.01 log units) below what was measured; measured number inside the range.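

In this assay, replacing (3-chlorophenyl)carbonyl with (3-chlorophenyl)(hydroxy)methyl on a saturated chain carbon bound to an aromatic carbon gives a 1.0-fold higher number from compound 1 to compound 4 (0.01 log units; within the scatter), the only step shown between compounds that differ in one place. At this place, then, the carbonyl and the hydroxy-bearing carbon cannot be told apart in this read-out, even though the entering group carries a hydrogen-bond donor that the leaving group lacks. Nothing measured here offers a cause for this result.

From the compounds shown here alone, whether an amine or a carboxylic acid at this place, or a longer chain, would also stay within the scatter of compound 1 remains open. Within the data shown here, compound 3 stands only as a limit, > 10000 nM, and no single-place step connects it to compound 4.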